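From 3-methoxyphenyl to 4-methoxyphenyl on a shared core

This account rests on a few compounds, and the source may have more. Where it says the series, first, only, none or still open, it means among the compounds named here.

In a functional assay on HeLa cells (Homo sapiens) for cytotoxicity, read by WST assay, with a stated time of 48 h (on this read-out lower numbers stand for stronger inhibition and higher numbers for weaker inhibition), compound 1 `COc1cccc([C@@H]2OC[C@H]([C@@H](O)c3ccc(OC)c(OC)c3)C[C@H]2C/C=C/c2ccc(OC)c(OC)c2)c1` gives 30100 nM. Compound 2 `COc1ccc([C@H](O)[C@H]2CO[C@@H](c3ccc(OC)c(OC)c3)[C@H](C/C=C/c3ccccc3)C2)cc1OC` gives 16100 nM, within the scatter of compound 1. Compound 3 `CCCCCC/C=C/C[C@H]1C[C@@H]([C@@H](O)c2ccccc2)CO[C@@H]1c1ccccc1` gives 7400 nM, a lower number than compound 1 and beyond the scatter. Compound 1 thus stands at the high end of these numbers, alongside compound 2. Compound 4 `COc1ccc([C@@H]2OC[C@H]([C@@H](O)c3ccc(OC)c(OC)c3)C[C@H]2C/C=C/c2ccc(OC)c(OC)c2)cc1` differs from compound 1 in one place: 4-methoxyphenyl in place of 3-methoxyphenyl on a saturated ring carbon, with 4-methoxyphenyl in place of 3-methoxyphenyl on a saturated ring carbon. Going by the values given here, no measured pair shows this change, so the data offer no direct guide to its size. The expected step, a 1.1-fold lower number from compound 1 to compound 4 (0.03 log units; within the scatter), stays within the scatter, with neither direction favoured. In this assay, compound 4 is estimated at 28000 nM, with an expected range of 12000 nM to 60000 nM.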

Compound 4, half-maximal inhibitory concentration: 29200 nM
Compound 4: middle estimate off by 1.0-fold (0.02 log units), on the low side; the range from low to high includes it.
By their numbers in this assay, from the lowest: compound 3; then compounds 2, 4 and 1 (each within the scatter of the next).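

In this assay, going by these compounds alone, 4-methoxyphenyl in place of 3-methoxyphenyl on a saturated ring carbon gives the first direct step at this position, a 1.0-fold lower number from compound 1 to compound 4 (0.01 log units; within the scatter), so this assay does not tell the two groups apart on the shared core. Nothing measured here offers a reason for this result.

The compounds shown leave open whether an aminophenyl or carboxyphenyl group on this ring carbon would move the number beyond the scatter. They also leave open whether the same exchange would stay within the scatter with a longer chain on the core.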